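A few compounds are considered here, and "the series" means these few. Any claim that something is new, unique, unknown or untested is made for them only; others in the source may bear on it.

Measured so far in a functional assay on MDA-MB-231 cells (Homo sapiens) for inhibition, read by sulforhodamine B assay; a higher number here means a weaker inhibitor of growth, a lower number a stronger inhibitor of growth:
- compound 1 `CC(=O)Nc1ccc(CN2CCC=C(CCC(=O)NO)C2=O)cc1`: "not determined" (no result reported)
- compound 2 `O=C(CCC1=CCCN(CCCc2ccc(-c3ccccc3)cc2)C1=O)NO`: 1040 nM

Compound 1 has no single number to stand on. Its entry reads "not determined" (no result reported), so its place in this assay is open, and nothing can be said about how strongly it holds back cell growth.

The next compound to be tested is compound 3 `O=C(CCC1=CCCN(Cc2ccc(Br)cc2)C1=O)NO`. It keeps the core of compound 1 but has bromo in place of acetamido on an aromatic carbon, para to a large group: bromo in place of acetamido on an aromatic carbon.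

Among the compounds with values here, no measured step shows what this kind of swap does. With no starting value, no direction can be expected, and the working expectation is a step of no size beyond the usual scatter. Within the data shown here, the only number available as a rough guide is that of compound 2, at 1040 nM, and a single value is a weak guide.

For compound 3, the expected value in this assay is 2000 nM, with an estimated range from 500 nM to 8000 nM.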

Compound 3, concentration for 50% growth inhibition: 1630 nM
Compound 3: the middle estimate sits 1.2-fold (0.09 log units) above what was measured, within the range that was stated.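

In this assay, within the data shown here, compound 3 gives 1630 nM while compound 1 has no number, and no step between compound 1 and compound 3 can be read. No measured evidence bears on this result. The compounds shown leave open what bromo in place of acetamido does to growth inhibition.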